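A few compounds are considered here, and "the series" means these few. Any claim that something is new, unique, unknown or untested is made for them only; others in the source may bear on it.

Measured compounds:
- compound 1, `COc1cc(Cl)cc(-c2nn(-c3cccc(NC(=O)Nc4ccc(Cl)c(C(F)(F)F)c4)c3)cc2-c2ccncc2)c1`: 87% in a functional assay on SNB-19 cells (Homo sapiens) for inhibition, read by sulforhodamine B assay, with a stated time of 48 h, tested at 1 uM; a lower number here means a stronger effect, a higher number a weaker effect of the compound at the concentration tested
- compound 2, `COc1cc(Cl)cc(-c2nn(-c3cccc(NC(=O)Nc4cccc(C(F)(F)F)c4)c3)cc2-c2ccncc2)c1`: 77% in this assay

Within the data shown here, compound 2 has the lowest of the two numbers in this assay; its nearest neighbour is compound 1, and the only measured step, a number 10 percentage points lower from compound 1 to compound 2 (within the scatter), lies within the scatter, so the two compounds cannot be told apart on these data. Both numbers are high, which here means a weak effect at the concentration tested.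

Compound 3, `COc1cc(Cl)cc(-c2nn(-c3cccc(NC(=O)c4cccc(C(F)(F)F)c4)c3)cc2-c2ccncc2)c1`, has not yet been measured. It differs from compound 2 in one place: 3-(trifluoromethyl)phenyl in place of (3-(trifluoromethyl)phenyl)amino on a carbonyl carbon. Among the measured compounds shown here, this turns the urea link of compound 2 into an amide link, and no measured step touches that part of the molecule; the step from compound 1 to compound 2 changed only a chloro on a distant ring and stayed within the scatter, so it gives no guide to this change. For the measured compounds named here, with no relevant step to lean on, the expectation for compound 3 is a number close to that of compound 2 with a wide range, the step of a number 5 percentage points higher from compound 2 to compound 3 (within the scatter) being expected to stay within the scatter. The estimate for compound 3 in this assay is 82%, between 62% and 102%.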

Compound 3, a percentage reported as activity, at one concentration (the size of the read-out at that concentration, not a potency): 100%
The estimate for compound 3 lay 18 percentage points below the measured number; low and high end bracket the measured number.
By their numbers in this assay, from the lowest: compounds 2 and 1 (each within the scatter of the next); then compound 3.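

In this assay, the urea link proves to be a place where a change can be read: 3-(trifluoromethyl)phenyl on the carbonyl carbon in place of (3-(trifluoromethyl)phenyl)amino gives a number 23 percentage points higher from compound 2 to compound 3 (beyond the scatter), which means a weaker effect at the concentration tested. Starting from the chloro-bearing urea, the change gives a number 13 percentage points higher from compound 1 to compound 3 (beyond the scatter), so the amide link gives a weaker effect than either urea, whereas the chloro change on the distant ring stayed within the scatter. The group that leaves counts one hydrogen-bond donor and the group that enters counts none, but no measurement shown connects that count to the result or explains it.

From the compounds shown here alone, whether the link can be altered without this weakening stays open, and a thiourea, or a urea with a methyl group on its nitrogen, would probe that question. A 4-chloro-3-(trifluoromethyl)phenyl group on the amide carbonyl would show whether the chloro change reads the same way with the amide link, and every comparison here still rests on a single concentration.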